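Methyl for Chloro on a Shared Phenoxypropanol Core

The source may hold more compounds than are shown below. What is called first, only, known or untested is meant among the compounds shown, and "the series" means these compounds.

The measured compounds:
compound 1, `Cc1cccc(Cl)c1OCC(C)O`, 2.73
compound 2, `CC(O)COc1ccc(Cl)cc1Cl`, 2.75
compound 3, `CC(O)COc1c(Cl)cccc1Cl`, 2.64

Of the compounds shown here, three have been measured in a physicochemical assay for lipophilicity, measured as octanol-water partition; a higher number here means a more lipophilic compound, a lower number a more polar compound. Compound 1 gives 2.73, compound 2 gives 2.75 and compound 3 gives 2.64. All three numbers lie within the scatter of one another, so no order among them can be claimed.

Compound 1 and compound 3 differ in one place, (methyl in place of chloro on an aromatic carbon). The step is a number 0.09 log units higher from compound 3 to compound 1 (within the scatter). Compound 2 and compound 3 contain the same atoms joined differently; the difference between the two cores is not broken down here.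

The unmeasured compound is compound 4, `Cc1cc(Cl)ccc1OCC(C)O`. It differs from compound 2 by methyl in place of chloro on an aromatic carbon. Among the compounds with values here, this is the same change as the one from compound 3 to compound 1: both remove a chloro group and put a methyl group on an aromatic carbon, ortho to a group of 5 heavy atoms and meta to a chloro group. That change has been seen once so far and moved this assay within the scatter.

Within the data shown here, the step from compound 2 to compound 4 is therefore expected to be a number 0.09 log units higher from compound 2 to compound 4 (within the scatter), resting on the single earlier step of a number 0.09 log units higher from compound 3 to compound 1 (within the scatter). Compound 4 is estimated at 2.84, between 2.55 and 3.15.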

Compound 4, partition coefficient: 2.84
Estimate against measurement, compound 4: no gap at the digits printed; measured number inside the range.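

In this assay the change of methyl in place of chloro on an aromatic carbon has now been read on two cores, once as a number 0.09 log units higher from compound 3 to compound 1 (within the scatter) and once as a number 0.09 log units higher from compound 2 to compound 4 (within the scatter). Within the data shown here, the two steps match at the digits printed, so within these two pairs the change carried from one core to the other, but both lie within the scatter, which means they show only that the change left this read-out little moved on either core, not that it has a real direction or a reliable size. Two pairs that share the same surroundings of the changed carbon set no rule for other cores, and no measurement at hand bears on why the two steps match.

The compounds shown leave open whether the same change would carry to a core in which an amine or a carboxylic acid stands in place of the hydroxyl group, or in which a longer chain replaces the one shared here. They also leave open whether another group in place of chloro, such as trifluoromethyl or methoxy, would give a step beyond the scatter on these same two cores.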